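The source may hold more compounds than are shown below. What is called first, only, known or untested is meant among the compounds shown, and "the series" means these compounds.

The measured compounds, in brief:

compound 1, `CCc1ccc(-c2nc3cc([N+](=O)[O-])ccc3[nH]2)cc1`, 1020 nM
compound 2, `O=[N+]([O-])c1ccc2nc(-c3ccccc3Cl)[nH]c2c1`, 10700 nM
compound 3, `CC(=O)c1ccc(-c2nc3cc([N+](=O)[O-])ccc3[nH]2)cc1`, 9320 nM

In a functional assay for antagonist activity at Neuropeptides B/W receptor type 1 (Homo sapiens), read by cAMP accumulation (a lower number here means a stronger inhibitor, a higher number a weaker inhibitor), compound 2 gives the highest of the three numbers. Compound 3 stands nearest to it, and the two are within the usual scatter of one another; compound 1 sits well apart, lower by more than the scatter allows. Among the compounds with values here, the only step that can be followed among the measured compounds, a 9.1-fold higher number from compound 1 to compound 3 (0.96 log units; beyond the scatter), changes a group on the phenyl ring in place of the ethyl and is of a different kind from the change now in question.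

Compound 4, `O=[N+]([O-])c1ccc2nc(-c3ccc(Cl)cc3Cl)[nH]c2c1`, differs from compound 2 by chloro in place of hydrogen on an aromatic carbon. Within the data shown here, no measured step covers adding a second chloro group to the phenyl ring, so the data offer no direct guide. With nothing to lean on, one expects the number for compound 4 to stay near that of compound 2, with the step of a 1.2-fold lower number from compound 2 to compound 4 (0.08 log units; within the scatter) lying within the scatter. The estimate for compound 4 in this assay is 9000 nM, with a range from 2500 nM to 30000 nM.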

Compound 4, half-maximal inhibitory concentration: 2880 nM
Compound 4: the middle estimate sits 3.1-fold (0.49 log units) above what was measured, and the stated range covers the measured number.
By their numbers in this assay, from the lowest: compound 1; then compound 4; then compounds 3 and 2 (each within the scatter of the next).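

In this assay, the step of a 3.7-fold lower number from compound 2 to compound 4 (0.57 log units; beyond the scatter) shows that this place on the ring, para to a large group and meta to a chloro group, is not indifferent to substitution: a single added chloro group moves the number beyond the scatter. The earlier step, a 9.1-fold higher number from compound 1 to compound 3 (0.96 log units; beyond the scatter), exchanged one group for another and raised the number, whereas this step adds a group where hydrogen stood and lowers it. Nothing measured here bears on why chloro has this effect at this place.

On these data alone, it remains open whether this chloro group would lower the number to a similar extent without the chloro group already on the ring. Also open, as far as these compounds go, is whether a methyl group, a methoxy group or an amine at the same place would match chloro.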